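Moving from 2-chlorophenyl to 3-chlorophenyl on the amide

A few compounds are considered here, and "the series" means these few. Any claim that something is new, unique, unknown or untested is made for them only; others in the source may bear on it.

In a functional assay on KB cells (Homo sapiens) for inhibition, read by MTT assay, with a stated time of 24 h, tested at 1 ug/mL (a higher number here means more inhibition of growth at the concentration tested, a lower number less inhibition of growth), compound 1 (`O=C(CCCCC(CCSC(=O)c1ccccc1)SC(=O)c1ccccc1)Nc1ccccc1`) is recorded as "not active" (no number reported). Within the data shown here, compound 2 (`O=C(CCCCC(CCSC(=O)c1ccccc1)SC(=O)c1ccccc1)Nc1ccccc1Cl`) gives 3.05%, the only number available so far, with little inhibition at the tested concentration. Compound 3 (`O=C(CCCCC(CCSC(=O)c1ccccc1)SC(=O)c1ccccc1)Nc1cccc(Cl)c1`) is the next to be read, and the change is 3-chlorophenyl in place of 2-chlorophenyl on an amide-type nitrogen. Among the measured compounds shown here, no measured step exists to calibrate this change, so no shift beyond the usual scatter is expected, in either direction. The expected change is a number 1 percentage points higher from compound 2 to compound 3 (within the scatter). For compound 3 the estimate is 4%, with an expected range of 0% to 12%.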

Compound 3, percent growth inhibition at one concentration: 12.7%
Beside the measured number, compound 3's estimate is 8.7 percentage points below it, and the stated range ends below it.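

In this assay, among these compounds, 3-chlorophenyl in place of 2-chlorophenyl on an amide-type nitrogen gives a number 9.7 percentage points higher from compound 2 to compound 3 (within the scatter) and is the first measured step at this place. The two chlorophenyl isomers therefore cannot be ranked, and compound 2 and compound 3 are not separated by this read-out. No measurement at hand bears on the result.

Still open, from the compounds shown here alone, is whether a carboxylic acid or an amine in place of the chlorine would give a step beyond the scatter. Going by these compounds, a longer chain on the shared core remains equally open.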